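Swapping the Halogenated Aryl Group on a Guanidine Urea

The compounds below may be only part of what the source reports. "The series", "measured", "known", "first", "only" and "open" are said of these compounds alone.

Compound 2, `Cc1nc(N)sc1CCCN/C(N)=N/C(=O)NC(C)c1cccc(F)c1`: 2.04 nM
Compound 3, `CCC(NC(=O)/N=C(\N)NCCCc1sc(N)nc1C)c1ccccc1`: 63.1 nM
Compound 1, `Cc1nc(N)sc1CCCN/C(N)=N/C(=S)NC(c1ccccc1)c1ccccc1`: 603 nM

In an assay on membranes from Sf9 cells for displacement of a labelled ligand from histamine H2 receptor (Homo sapiens), read by scintillation counting, with a stated time of 60 min (on this read-out higher numbers stand for weaker inhibition and lower numbers for stronger inhibition), compound 2 gives the lowest number of the three. Compound 3 stands nearest to it and compound 1 furthest away, and both gaps lie beyond the scatter, so compound 2 is the strongest inhibitor among the measured compounds. Compound 4 `Cc1nc(N)sc1CCCN/C(N)=N/C(=O)NC(C)c1ccc(Cl)cc1` differs from compound 2 in one place only: 4-chlorophenyl in place of 3-fluorophenyl on a saturated chain carbon bound to an amide-type nitrogen and a saturated chain carbon. Among the compounds with values here, no measured pair shows this kind of change, so its effect is not known from the data. The step from compound 2 to compound 4 is expected to be a 2.5-fold higher number from compound 2 to compound 4 (0.39 log units; beyond the scatter), a small weakening that may stay within the scatter. Compound 4 is expected to give 5 nM, in the range 1.5 nM to 20 nM.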

Compound 4, inhibition constant: 46.8 nM
Compound 4: middle estimate off by 9.4-fold (0.97 log units), on the low side; measured number above the stated range.
By their numbers in this assay, from the lowest: compound 2; then compounds 4 and 3 (each within the scatter of the next); then compound 1.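

In this assay the aryl group on this saturated chain carbon proves to matter: 4-chlorophenyl in place of 3-fluorophenyl gives a 23-fold higher number from compound 2 to compound 4 (1.36 log units; beyond the scatter) even though the two groups match in heavy-atom count, hydrogen-bond donors and acceptors, and charge. No measurement here explains this step. From the compounds shown here alone, the step changes both the halogen and its place on the ring, so the share of each remains open. A 3-chlorophenyl or 4-fluorophenyl group would separate the two, and how a nitrile would fare here is also unknown.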